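The source may hold more compounds than are shown below. What is called first, only, known or untested is meant among the compounds shown, and "the series" means these compounds.

In a functional assay on MCF7 cells (Homo sapiens) for antiproliferative activity, read by sulforhodamine B assay (on this read-out higher numbers stand for weaker inhibition and lower numbers for stronger inhibition), three compounds sharing one core have been measured. Compound 1 (`CN1CCN(c2ccc(N/C=C3\C(=O)NC(=O)c4ccc(-n5cccc5)cc43)cc2)CC1`) gives 2300 nM, compound 2 (`O=C1NC(=O)c2ccc(-n3cccc3)cc2/C1=C/Nc1ccc(CN2CCCCC2)cc1`) gives 2100 nM, and compound 3 (`CN1CCN(c2ccc(N/C=C3\C(=O)NC(=O)c4ccc(-c5ccsc5)cc43)cc2)CC1`) gives 2300 nM, so compound 2 stands within the scatter of both others. Compound 4 (`O=C1NC(=O)c2ccc(-c3ccoc3)cc2/C1=C/Nc1ccc(CN2CCCCC2)cc1`) keeps the (piperidin-1-yl)methyl group of compound 2 and changes one substituent, with furan-3-yl in place of 1H-pyrrol-1-yl on an aromatic carbon. The closest measured precedent is thiophen-3-yl in place of the same 1H-pyrrol-1-yl, which gives no change at the digits printed from compound 1 to compound 3 (within the scatter). The other measured exchange, (piperidin-1-yl)methyl in place of 4-methylpiperazin-1-yl, gives a 1.1-fold lower number from compound 1 to compound 2 (0.04 log units; within the scatter). Going by the values given here, neither step leaves the scatter, although no furan-3-yl compound has yet been measured. Resting on compound 3 at 2300 nM, no step beyond the scatter is expected in this assay, in either direction. The expected step is no change at the digits printed from compound 2 to compound 4 (within the scatter). For compound 4 the estimated value is 2100 nM, with an expected range of 900 nM to 4500 nM.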

Compound 4, half-maximal inhibitory concentration: 1100 nM
Estimate against measurement, compound 4: 1.9-fold (0.28 log units) above, and the stated range covers the measured number.
By their numbers in this assay, from the lowest: compounds 4, 2, 1 and 3 (each within the scatter of the next, the first and the last beyond it).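

In this assay, furan-3-yl in place of 1H-pyrrol-1-yl on an aromatic carbon, with the (piperidin-1-yl)methyl group kept, gives a 1.9-fold lower number from compound 2 to compound 4 (0.28 log units; within the scatter). The earlier compounds shown here showed an exchange at this position only alongside 4-methylpiperazin-1-yl and only with thiophen-3-yl; this step extends the picture to a second entering five-membered aromatic ring with 1 hetero atom and to the other side chain, and it too stays within the scatter. No information is at hand that bears on this result.

The compounds shown leave open whether this position behaves the same way with something other than a five-membered aromatic ring, such as a phenyl ring, an amine or a carboxylic acid. They also leave open what thiophen-3-yl gives alongside (piperidin-1-yl)methyl.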